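The compounds below may be only part of what the source reports. "The series", "measured", "known", "first", "only" and "open" are said of these compounds alone.

Measured so far:
Compound 1 `Cc1cc(C)n(-c2nc(-c3ccncc3)cc(=O)[nH]2)n1`: > 50000 nM
Compound 2 `Cc1cc(N)n(-c2nc(C(F)(F)F)cc(=O)[nH]2)n1`: 120000 nM

Within the data shown here, only two compounds have been tested in an ADME assay on CHO cells (Cricetulus griseus) for cytotoxicity, read by MTT assay; a higher number here means a weaker inhibitor, a lower number a stronger inhibitor. Compound 1 gives > 50000 nM, which is a limit of the assay and not a number. Among the measured compounds shown here, compound 2 gives 120000 nM, the only exact number available, so it is the natural reference point for what follows.

Compound 3 `COCCNc1cc(C)nn1-c1nc(C(F)(F)F)cc(=O)[nH]1` is compound 2 with a single change: 2-methoxyethyl in place of hydrogen on a nitrogen on an aromatic ring. Put in words, 2-methoxyethyl takes the place of hydrogen on a nitrogen on an aromatic ring, turning amino into (2-methoxyethyl)amino.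

For the measured compounds named here, no pair of measured compounds differs in one place, so the data give no direct guide to the size of this step. The expectation therefore starts from compound 2 at 120000 nM and assumes no shift beyond the usual scatter in this assay. The expected change is a 1.3-fold lower number from compound 2 to compound 3 (0.12 log units; within the scatter). The assay may also report only a limit for this compound. Compound 3 is estimated at 90000 nM, with an expected range of 30000 nM to 250000 nM.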

Compound 3, half-maximal inhibitory concentration: 17000 nM
For compound 3 the middle estimate is 5.3-fold (0.72 log units) above the measured one; the whole stated range lies above it.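

Among these compounds, replacing a hydrogen on the amino nitrogen with a 2-methoxyethyl chain gives a 7.1-fold lower number from compound 2 to compound 3 (0.85 log units; beyond the scatter) in this assay, the first measured step in this small set. A lower number here means stronger inhibition, so this nitrogen is a position where a substituent can change the reading by more than the usual scatter, and this change moves it towards greater effect on the cells. The starting value of compound 2 is at the high end of what is shown, and one caution about reading across the set is that compound 1 is reported only as a limit, not a number: the limit of > 50000 nM in this assay, at which 1 of the 3 values shown sits.

With only this one substituent at this position, the result cannot separate the contribution of the chain itself from that of its ether oxygen; a plain ethyl chain, a longer chain without oxygen, or a chain ending in an amine or a carboxylic acid would each help to do so. On these data alone, whether the same change would have a similar effect on the core of compound 1 also remains open.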